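Changing One Aromatic Ring on a Shared Core

The source may report more compounds than this note shows. Statements on the series, on what has been measured and on what is new or still open speak of the compounds shown alone.

Compound 1 `COc1cc(C=C(C(=O)/C=C/c2cccc(OC)c2OC)C(=O)/C=C/c2cccc(OC)c2OC)ccc1O`, compound 2 `COc1cccc(/C=C/C(=O)C(=Cc2ccc(O)c(F)c2)C(=O)/C=C/c2cccc(OC)c2OC)c1OC` and compound 3 `COc1cc(C=C(C(=O)/C=C/c2cccc(OC)c2OC)C(=O)/C=C/c2cccc(OC)c2OC)cc(Br)c1O` share one core and differ only in the aromatic ring on a double-bonded chain carbon. In a functional assay on MCF7 cells (Homo sapiens) for antiproliferative activity, read by sulforhodamine B assay, with a stated time of 48 h (on this read-out higher numbers stand for weaker inhibition and lower numbers for stronger inhibition), compound 1 gives 480 nM, compound 2 gives 300 nM and compound 3 gives 360 nM. These numbers lie within the scatter of each other, so compound 3 stands level with the other two.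

Compound 4 `COc1cccc(/C=C/C(=O)C(=Cc2ccc(OC)c(OC)c2OC)C(=O)/C=C/c2cccc(OC)c2OC)c1OC` carries 2,3,4-trimethoxyphenyl in place of 3-bromo-4-hydroxy-5-methoxyphenyl on a double-bonded chain carbon bound to a double-bonded chain carbon.

Three measured steps involve this same ring: a 1.6-fold lower number from compound 1 to compound 2 (0.20 log units; within the scatter), a 1.3-fold lower number from compound 1 to compound 3 (0.12 log units; within the scatter) and a 1.2-fold higher number from compound 2 to compound 3 (0.08 log units; within the scatter). All of them stay within the scatter, so changes to this ring have so far moved the number little. However, compound 1, compound 2 and compound 3 all keep a hydroxy group on this ring, and compound 4 does not. For the measured compounds named here, no measured compound shows what losing it does.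

A step beyond the scatter is therefore not expected in this assay, though the range has to stay wide. The expected step is a 1.3-fold higher number from compound 3 to compound 4 (0.10 log units; within the scatter). Compound 4 is estimated at 450 nM, with an expected range from 150 nM to 1400 nM.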

Compound 4, half-maximal inhibitory concentration: 380 nM
For compound 4 the middle estimate is 1.2-fold (0.07 log units) above the measured one, within the range that was stated.
By their numbers in this assay, from the lowest: compounds 2, 3, 4 and 1 (each within the scatter of the next).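

In this assay, the steps to the new compound are a 1.1-fold higher number from compound 3 to compound 4 (0.02 log units; within the scatter), a 1.3-fold higher number from compound 2 to compound 4 (0.10 log units; within the scatter) and a 1.3-fold lower number from compound 1 to compound 4 (0.10 log units; within the scatter), and all three stay within the scatter. This settles the question the earlier compounds left open: compound 4 has no hydroxy group on this ring, and 2,3,4-trimethoxyphenyl has 0 hydrogen-bond donors, yet its number stays level with those of the three compounds that keep the hydroxy group, so among these four compounds that group is not required for a number of this size. No measurement here gives a reason for this result.

On these data alone, all four compounds carry a phenyl ring at this position, with only hydroxy, methoxy, fluoro or bromo groups on it, so it remains open whether an amine, a carboxylic acid or a longer chain on the ring would move the number beyond the scatter. The rest of the shared core is the same in all four compounds, so they say nothing about how changes there would affect the number.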